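A few compounds are considered here, and "the series" means these few. Any claim that something is new, unique, unknown or untested is made for them only; others in the source may bear on it.

Compound 1 `COC(=O)[C@@]1(C)CC[C@@H]2C3=C1CC[C@@H](C)[C@]3(C)Cc1c2[nH]c2ccccc12` gives 3500 nM in a functional assay on HBL-100 cells (Homo sapiens) for inhibition, read by sulforhodamine B assay, with a stated time of 48 h (on this read-out higher numbers stand for weaker inhibition of growth and lower numbers for stronger inhibition of growth), the lowest of the three numbers shown, though its gap to compound 3 stays within the scatter. Compound 2 `COC(=O)[C@@]1(C)CC[C@@H]2C3=C1CC[C@@H](C)[C@]3(C)Cc1c2[nH]c2ccc(C)cc12` gives 11000 nM in this assay, and compound 3 `COC(=O)[C@@]1(C)CC[C@@H]2C3=C1CC[C@@H](C)[C@]3(C)Cc1c2[nH]c2ccc(OC)cc12` gives 5000 nM. Compound 4 `COC(=O)[C@@]1(C)CC[C@@H]2C3=C1CC[C@@H](C)[C@]3(C)Cc1c2[nH]c2c(Br)cccc12` differs from compound 1 by bromo in place of hydrogen on an aromatic carbon. Among the compounds with values here, the steps that bear on this change are the two other substitutions on an aromatic carbon: a 3.1-fold higher number from compound 1 to compound 2 (0.50 log units; beyond the scatter) and a 1.4-fold higher number from compound 1 to compound 3 (0.15 log units; within the scatter). Neither lowered the number, so a bromo group is expected to leave the number roughly unchanged or push it modestly upward, an expected step of a 1.4-fold higher number from compound 1 to compound 4 (0.15 log units; within the scatter). Compound 4 is therefore estimated at 5000 nM, with a range from 2000 nM to 15000 nM.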

Compound 4, concentration for 50% growth inhibition: 26000 nM
Beside the measured number, compound 4's estimate is 5.2-fold (0.72 log units) below it, outside the stated range (above it).
By their numbers in this assay, from the lowest: compounds 1 and 3 (each within the scatter of the next); then compound 2; then compound 4.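

In this assay, bromo in place of hydrogen, ortho to a fused ring and meta to a fused ring, gives a 7.4-fold higher number from compound 1 to compound 4 (0.87 log units; beyond the scatter). This is the largest step away from compound 1 so far, larger than a 3.1-fold higher number from compound 1 to compound 2 (0.50 log units; beyond the scatter), and it marks a clear loss of growth inhibition with this change. No available evidence accounts for the size of this step. The compounds shown leave open whether the step belongs to bromo itself or to this position. Fluoro, an amine or a hydroxyl group on this carbon, or bromo on another aromatic carbon, would separate the two.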